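The compounds below may be only part of what the source reports. "The series", "measured", "known", "first", "only" and "open" are said of these compounds alone.

Measured so far:
compound 1 `COc1ccc(/C=C/C(=O)c2ccccc2-c2ccc(F)nc2)cc1` gives 160 nM
compound 2 `COc1ccc(/C=C/C(=O)c2ccccc2-c2cccc(F)c2)cc1OC` gives 650 nM

In a functional assay on CNE-2 cells (Homo sapiens) for antiproliferative activity, read by sulforhodamine B assay, with a stated time of 48 h (a higher number here means a weaker inhibitor, a lower number a stronger inhibitor), compound 2 gives 650 nM as the higher of the two numbers, beyond the scatter from compound 1. Compound 3 `COc1ccc(/C=C/C(=O)c2ccccc2-c2ccc(F)nc2)cc1OC` has 6-fluoropyridin-3-yl in place of 3-fluorophenyl on an aromatic carbon and has not yet been measured. Compound 1, which also bears 6-fluoropyridin-3-yl, gives 160 nM and so points to a lower number. The expected move is moderate but beyond the scatter, an estimated step of a 3.0-fold lower number from compound 2 to compound 3 (0.47 log units; beyond the scatter) towards stronger inhibition. The estimated value for compound 3 is 220 nM within a range of 70 nM to 650 nM.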

Compound 3, half-maximal inhibitory concentration: 1600 nM
Compound 3: the middle estimate sits 7.3-fold (0.86 log units) below what was measured; measured number outside the range, above it.
By their numbers in this assay, from the lowest: compound 1; then compound 2; then compound 3.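

In this assay 6-fluoropyridin-3-yl in place of 3-fluorophenyl on an aromatic carbon gives a 2.5-fold higher number from compound 2 to compound 3 (0.39 log units; beyond the scatter) when the core carries both methoxy groups, so the low number of compound 1 does not carry over to this core. Methoxy in place of hydrogen on an aromatic carbon brings a 10-fold higher number from compound 1 to compound 3 (1.00 log units; beyond the scatter) with 6-fluoropyridin-3-yl held fixed, the larger of the two steps. No measurement offered here explains either step.

On these data alone, whether the added methoxy costs as much with 3-fluorophenyl in place stays open. So does how an amine or a plain phenyl would read at this position.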